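The source may hold more compounds than are shown below. What is called first, only, known or untested is meant among the compounds shown, and "the series" means these compounds.

Compound 1, with the structure `Nc1nnc(SC[C@H]2O[C@@H](OCc3noc(-c4ccc(Cl)cc4)n3)[C@@H]3OC4(CCCC4)O[C@@H]32)s1`, was tested in a functional assay on T47D cells (Homo sapiens) for antiproliferative activity, read by sulforhodamine B assay, with a stated time of 48 h (on this read-out lower numbers stand for stronger inhibition of growth and higher numbers for weaker inhibition of growth), and gave 18000 nM. Compound 2, `O=[N+]([O-])c1ccc(-c2nc(CO[C@@H]3O[C@H](CSc4ncn[nH]4)[C@H]4OC5(CCCC5)O[C@@H]34)no2)cc1`, gave 20000 nM in the same assay, a number within the usual scatter of that of compound 1, so the two cannot be told apart. Compound 3, `CC1(C)O[C@H]2[C@H](OCc3noc(-c4ccc([N+](=O)[O-])cc4)n3)O[C@H](CSc3nnc(N)s3)[C@H]2O1`, reached only a limit of the assay, > 100000 nM, rather than a number, as noted in the limit of > 100000 nM in this assay, at which 1 of the 3 values shown sits. The next compound, compound 4 with the structure `Nc1nnc(SC[C@H]2O[C@@H](OCc3noc(-c4ccc([N+](=O)[O-])cc4)n3)[C@@H]3OC4(CCCC4)O[C@@H]32)s1`, differs from compound 1 in one place: nitro in place of chloro on an aromatic carbon. The two measured values that stand near each other give no reason to expect a step beyond the scatter. Compound 4 is therefore estimated at 20000 nM, with a likely range of 8000 nM to 60000 nM, which would mean a step of a 1.1-fold higher number from compound 1 to compound 4 (0.05 log units; within the scatter).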

Compound 4, concentration for 50% growth inhibition: 19000 nM
For compound 4 the middle estimate is 1.1-fold (0.02 log units) above the measured one; the range from low to high includes it.
By their numbers in this assay, from the lowest: compounds 1, 4 and 2 (each within the scatter of the next). At a limit, above all of these: compound 3.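

In this assay, nitro in place of chloro on the six-membered aromatic ring, para to a large group, gives a 1.1-fold higher number from compound 1 to compound 4 (0.02 log units; within the scatter), so the two groups cannot be told apart at this position. With 5-amino-1,3,4-thiadiazol-2-yl in place of 1H-1,2,4-triazol-5-yl on the sulfur, the result is a 1.1-fold lower number from compound 2 to compound 4 (0.02 log units; within the scatter), so these two groups cannot be told apart either. Compound 3 differs from compound 4 in one place, elsewhere in the structure, and stands at a limit: the limit of > 100000 nM in this assay, at which 1 of the 4 values shown sits.

The compounds shown leave open how an amine or a carboxylic acid would read at this position on the aromatic ring.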